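A few compounds are considered here, and "the series" means these few. Any claim that something is new, unique, unknown or untested is made for them only; others in the source may bear on it.

Compound 1 `O=S(=O)(NCCCNc1nccc(-c2c(-c3cccc(F)c3)nc3sccn23)n1)c1ccc(Br)cc1`, compound 2 `O=S(=O)(NCCCNc1nccc(-c2c(-c3cccc(F)c3)nc3sccn23)n1)c1ccc(F)cc1` and compound 3 `O=S(=O)(NCCNc1nccc(-c2c(-c3cccc(F)c3)nc3sccn23)n1)c1cccc(F)c1` share one core and differ only in their sulfonyl-bearing tails. In a functional assay on SK-MEL-28 cells (Homo sapiens) for cytotoxicity, read by MTT assay (on this read-out lower numbers stand for stronger inhibition and higher numbers for weaker inhibition), compound 1 gives 9400 nM and compound 3 gives 18300 nM. For compound 2 this assay reports only a limit, > 20000 nM. Compound 3 and compound 1 lie within the scatter of each other, as a 1.9-fold higher number from compound 1 to compound 3 (0.29 log units; within the scatter) shows. Compound 4 `O=C(NCCCNc1nccc(-c2c(-c3cccc(F)c3)nc3sccn23)n1)c1ccc(Cl)cc1` is not yet measured; it carries (((4-chlorophenyl)carbonyl)amino)methyl in place of ((3-fluorophenyl)sulfonyl)amino on a saturated chain carbon, two bonds along the chain from a nitrogen on an aromatic ring. Among the compounds with values here, the two steps that touched this place, a 1.9-fold higher number from compound 1 to compound 3 (0.29 log units; within the scatter) and an at least 1.0-fold lower number from compound 2 to compound 3 (0.03 log units; that floor lies within the scatter), both stayed within the scatter, and no measured step exchanges sulfonyl for carbonyl or fluoro for chloro there. The step expected in this assay is a 1.2-fold lower number from compound 3 to compound 4 (0.09 log units; within the scatter), nothing beyond the scatter. Compound 4 is estimated at 15000 nM, between 6000 nM and 40000 nM.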

Compound 4, half-maximal inhibitory concentration: > 20000 nM
Compound 4: no number, only a limit (the forecaster's own chance of this, stated with the estimate: 35%); middle value at least 1.3-fold (0.12 log units) from the limit.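

Within the data shown here, replacing the sulfonyl link with a carbonyl at this place gives the first readable change beyond the scatter in this assay: the (4-chlorophenyl)carbonyl tail shows an at least 2.1-fold higher number from compound 1 to compound 4 (0.32 log units; beyond the scatter). Against the shorter tail, the floor says little, with an at least 1.0-fold higher number from compound 3 to compound 4 (0.03 log units; that floor lies within the scatter). Compound 2 and compound 4 each give only a limit, so the step between them cannot be read: the limit of > 20000 nM in this assay, at which 2 of the 4 values shown sit.

Compound 1 and compound 4 differ in both the link and the halogen, so the two changes stay unseparated. On these data alone, the effect of an amine or a longer chain in this tail also remains open.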